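The source may report more compounds than this note shows. Statements on the series, on what has been measured and on what is new or still open speak of the compounds shown alone.

Compound 1 `COc1cccc(N2CCN(C(=O)c3oc(C)nc3-c3ccccc3F)CC2)c1` carries a single methoxy group on one aryl ring of its core, and in a functional assay on HL-60 cells (Homo sapiens) for inhibition, read by MTT assay, with a stated time of 72 h (on this read-out lower numbers stand for stronger inhibition and higher numbers for weaker inhibition), compound 1 gives 56.1 nM. Compound 2 `COc1cc(OC)cc(N2CCN(C(=O)c3oc(C)nc3-c3ccccc3F)CC2)c1` differs from it only by methoxy in place of hydrogen on an aromatic carbon. In this assay compound 2 gives 10.3 nM, so that a 5.4-fold lower number from compound 1 to compound 2 (0.74 log units; beyond the scatter). Compound 3 `CCc1nc(-c2ccc(OC)cc2)c(C(=O)N2CCN(c3cccc(Cl)c3)CC2)o1` has another core, and how it differs from compound 1 is not broken down here. In this assay compound 3 gives only a limit, > 1000 nM. This is the limit of the measurement itself, (the limit of > 1000 nM in this assay, at which 1 of the 3 values shown sits), not a number. Compound 4 `CCc1nc(-c2ccc(OC)c(OC)c2)c(C(=O)N2CCN(c3cccc(Cl)c3)CC2)o1`, not yet measured, differs from compound 3 by methoxy in place of hydrogen on an aromatic carbon. Within the data shown here, this is the same kind of change as the one from compound 1 to compound 2, but not the same: here the new methoxy sits ortho to a methoxy group, whereas in compound 2 it sits meta to a methoxy group. Since compound 3 offers only a limit, the step from compound 3 to compound 4 is expected to be a step that the limit leaves unreadable from compound 3 to compound 4, resting on the earlier 5.4-fold lower number from compound 1 to compound 2 (0.74 log units; beyond the scatter). Compound 4 is therefore estimated at 1500 nM, between 300 nM and 6000 nM.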

Compound 4, half-maximal inhibitory concentration: "not active" (no number reported)
Compound 4: no number reported, so the estimate cannot be set against anything.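

No new step can be read from compound 3 to compound 4, since compound 4 is reported as "not active" with no number and compound 3 offers only a limit: the limit of > 1000 nM in this assay, at which 1 of the 4 values shown sits.

Going by these compounds, whether going from 4-methoxyphenyl to 3,4-dimethoxyphenyl shifts the number at all, and whether any shift would match a 5.4-fold lower number from compound 1 to compound 2 (0.74 log units; beyond the scatter), stays open.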